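Chloro to Hydroxy: What the Three Measured Compounds Suggest

The source may report more compounds than this note shows. Statements on the series, on what has been measured and on what is new or still open speak of the compounds shown alone.

Of the compounds shown here, three sharing one core have been tested in a functional assay on the whole organism (strain Wistar) for inhibition, with Rattus norvegicus as the target, read by paw edema, with a stated time of 4 h, at a dose of 10 mg/kg by the intraperitoneal route; on this read-out lower numbers stand for less inhibition and higher numbers for more inhibition at the one dose given (going by the name of the read-out). Compound 1 `O=C(N/N=C/c1ccccc1)c1cccnc1Nc1cccc(C(F)(F)F)c1` gives 31%. Compound 2 `O=C(N/N=C/c1cccc(Cl)c1)c1cccnc1Nc1cccc(C(F)(F)F)c1` gives 40.4%, and compound 3 `O=C(N/N=C/c1ccc(Cl)cc1)c1cccnc1Nc1cccc(C(F)(F)F)c1` gives 43.7%. Compound 2 thus stands second highest of the three numbers, yet the step of a number 3.3 percentage points higher from compound 2 to compound 3 (within the scatter) and the step of a number 9.4 percentage points higher from compound 1 to compound 2 (within the scatter) are both within the scatter, so the three cannot be placed in a firm order.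

Compound 4 `O=C(N/N=C/c1cccc(O)c1)c1cccnc1Nc1cccc(C(F)(F)F)c1` has not yet been measured. It differs from compound 2 in one place: hydroxy in place of chloro on an aromatic carbon. Among the measured compounds shown here, only one measured step touches this place, the one in which chloro entered in place of hydrogen, a number 9.4 percentage points higher from compound 1 to compound 2 (within the scatter), and it stayed within the scatter; the step of a number 12.7 percentage points higher from compound 1 to compound 3 (beyond the scatter) concerns the other chloro compound and was modest. For the measured compounds named here, no measured compound carries a hydroxy, so what that group brings is unknown from these data. Taking the chloro away would be expected to move the number back toward that of compound 1, with the hydroxy an open question. Compound 4 is therefore expected to give about 33%, within a range from 22% to 45%. The expected step of a number 7.4 percentage points lower from compound 2 to compound 4 (within the scatter) is not beyond the scatter.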

Compound 4, a percentage reported as inhibition, in the whole organism at one dose (the size of the read-out at that dose, not a potency): 35.8%
Compound 4: the middle estimate sits 2.8 percentage points below what was measured; low and high end bracket the measured number.
By their numbers in this assay, from the lowest: compounds 1, 4, 2 and 3 (each within the scatter of the next, the first and the last beyond it).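

At this place on the aromatic ring, hydroxy and chloro cannot be told apart in this assay, since the step of a number 4.6 percentage points lower from compound 2 to compound 4 (within the scatter) stays within the scatter. The first hydroxy group measured also cannot be separated from plain hydrogen, as the step of a number 4.8 percentage points higher from compound 1 to compound 4 (within the scatter) is within the scatter too, so compound 4 sits level with both the chloro compound and the unsubstituted one, and the step of a number 7.9 percentage points lower from compound 3 to compound 4 (within the scatter) places it level with compound 3 as well, even though compound 3 and compound 1 stand apart beyond the scatter. Nothing measured here speaks to why these groups give the numbers they do.

Still open, on these data alone, is whether any other group at this place, such as an amine, a methoxy or a carboxylic acid, would move the number beyond the scatter in either direction. Also open, as far as these compounds go, is whether hydroxy in the place the chloro holds in compound 3 would give the same picture, and, with only one dose read, how these compounds would compare at other doses.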